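The compounds below may be only part of what the source reports. "The series", "measured", "known", "first", "only" and "open" are said of these compounds alone.

The series shares one core, varied only in the aryl on the amide-type nitrogen. Compound 1 `CN(C)CCNc1nc(-c2ccc(NC(=O)Nc3ccc(F)cc3)cc2)nc2c(Cl)c(Cl)sc12` gives 890 nM in a functional assay on HT-29 cells (Homo sapiens) for cytotoxicity, read by MTT assay, with a stated time of 72 h; a higher number here means a weaker inhibitor, a lower number a stronger inhibitor. Compound 2 `CN(C)CCNc1nc(-c2ccc(NC(=O)Nc3ccc(Cl)cc3)cc2)nc2c(Cl)c(Cl)sc12` gives 460 nM in this assay, and compound 3 `CN(C)CCNc1nc(-c2ccc(NC(=O)Nc3ccccc3Cl)cc2)nc2c(Cl)c(Cl)sc12` gives 570 nM in this assay. Compound 3 thus sits between the other two numbers, with a 1.2-fold higher number from compound 2 to compound 3 (0.09 log units; within the scatter) and a 1.6-fold lower number from compound 1 to compound 3 (0.19 log units; within the scatter), so neither gap separates it from its neighbours. Compound 4 `CN(C)CCNc1nc(-c2ccc(NC(=O)Nc3ccc(Cl)cc3Cl)cc2)nc2c(Cl)c(Cl)sc12` is reached by chloro in place of hydrogen on an aromatic carbon. Going by the values given here, two measured steps bear on this: a 1.9-fold lower number from compound 1 to compound 2 (0.29 log units; within the scatter), which exchanges one halogen for another, and a 1.2-fold higher number from compound 2 to compound 3 (0.09 log units; within the scatter), which relocates the single chloro group; compound 4 now carries both chloro groups at once. Every step seen so far stayed within the scatter, so nothing beyond the scatter is expected here, with, if anything, a lean toward a lower number given a 1.9-fold lower number from compound 1 to compound 2 (0.29 log units; within the scatter). Compound 4 is therefore estimated at 450 nM, within a range from 200 nM to 1000 nM, which would mean a 1.3-fold lower number from compound 3 to compound 4 (0.10 log units; within the scatter).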

Compound 4, half-maximal inhibitory concentration: 1280 nM
For compound 4 the middle estimate is 2.8-fold (0.45 log units) below the measured one; the measured number lies above the stated range.
By their numbers in this assay, from the lowest: compounds 2, 3, 1 and 4 (each within the scatter of the next, the first and the last beyond it).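

Adding a second chloro group produces the first steps in this series that go beyond the scatter: in this assay there is a 2.2-fold higher number from compound 3 to compound 4 (0.35 log units; beyond the scatter) and a 2.8-fold higher number from compound 2 to compound 4 (0.44 log units; beyond the scatter), so the two chloro groups that each read alike on their own do not behave alike when they share the ring. Set against the 4-fluorophenyl group, the 2,4-dichlorophenyl group gives a 1.4-fold higher number from compound 1 to compound 4 (0.16 log units; within the scatter), which leaves compound 4 not separable from compound 1. No measurement shown here accounts for this result.

Whether the shift belongs to the number of chloro groups or to this particular pairing on the ring remains open, with compound 4 the only doubly substituted ring shown. The compounds also leave open how a methoxy group, a trifluoromethyl group or an amine would read on this ring.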